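The source may hold more compounds than are shown below. What is called first, only, known or untested is meant among the compounds shown, and "the series" means these compounds.

Compounds measured so far:

Compound 1, `CCCc1ccc(/C=C/C(=O)Nc2ccc3nc(CCC)cc(N)c3c2)cc1`, in an assay on isolated protein for displacement of a labelled ligand from melanin-concentrating hormone receptor 1 (Homo sapiens) (a lower number here means a stronger inhibitor, a higher number a weaker inhibitor), gives 4 nM.
Compound 2, `CCCc1cc(N2CCCC2)c2cc(NC(=O)/C=C/c3ccc(C(F)(F)F)cc3)ccc2n1`, in this assay gives 17 nM.

Compound 2 has the higher of the two numbers; compound 1 sits at a lower number, and that gap is beyond the usual scatter. Going by the values given here, no step between these two is set out, since they differ in more than one place, so only their two values can be compared.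

Compound 3, `CCCc1cc(N(C)C)c2cc(NC(=O)/C=C/c3ccc(C(F)(F)F)cc3)ccc2n1`, has not yet been measured. It differs from compound 2 in one place: dimethylamino in place of pyrrolidin-1-yl on an aromatic carbon. Among the compounds with values here, no measured pair shows a step of this kind, so the direction is open; the change is expected to give at most a small step, within or just beyond the scatter, and more likely towards a somewhat higher number. For compound 3 the expected value in this assay is 25 nM, with a range from 8 nM to 80 nM, which means an estimated step of a 1.5-fold higher number from compound 2 to compound 3 (0.17 log units; within the scatter).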

Compound 3, half-maximal inhibitory concentration: 43 nM
Estimate against measurement, compound 3: 1.7-fold (0.24 log units) below; the measured number falls inside the stated range.
By their numbers in this assay, from the lowest: compound 1; then compound 2; then compound 3.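

In this assay, going by these compounds alone, this is the first pair that differs only at the amine on the aromatic carbon opposite the ring nitrogen, so the position can now be read directly. Dimethylamino in place of pyrrolidin-1-yl gives a 2.5-fold higher number from compound 2 to compound 3 (0.40 log units; beyond the scatter) and shows that the number responds to this change, although the step is modest. The open-chain group gives the higher number of the pair, and compound 3 remains an inhibitor in the same assay, so the ring is not essential for inhibition. Nothing available explains this step.

A single pair cannot separate the loss of the ring from the loss of heavy atoms, and diethylamino, which has no ring, or piperidin-1-yl, a larger ring, would bear on that. As far as these compounds go, whether morpholin-4-yl is tolerated here, and whether the step holds with the propyl group of compound 1 in place of trifluoromethyl, also remain open.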